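This account rests on a few compounds, and the source may have more. Where it says the series, first, only, none or still open, it means among the compounds named here.

Among the compounds with values here, in a functional assay on EOL1 cells (Homo sapiens) for inhibition, read by fluorescence, with a stated time of 72 h (a lower number here means a stronger inhibitor of growth, a higher number a weaker inhibitor of growth), compound 1 `CC(C)CCn1cnc2c(Nc3ccc(Cl)cc3)nc(N[C@H]3CC[C@H](N)CC3)nc21` gives 90 nM, the lowest of the three numbers measured so far. Compound 2 `CCCCCCn1cnc2c(Nc3ccc(O)cc3)nc(N[C@H]3CC[C@H](N)CC3)nc21` gives 190 nM and compound 3 `N[C@H]1CC[C@H](Nc2nc(Nc3ccc(O)cc3)c3ncn(C4CCCCC4)c3n2)CC1` gives 220 nM, and both lie beyond the scatter from compound 1. The next molecule, compound 4 `CC(C)CCn1cnc2c(Nc3cccc(Cl)c3)nc(N[C@H]3CC[C@H](N)CC3)nc21`, differs from compound 1 by one change, 3-chlorophenyl in place of 4-chlorophenyl on a nitrogen on an aromatic ring. Within the data shown here, only one measured step bears on this even indirectly, a 1.2-fold higher number from compound 2 to compound 3 (0.06 log units; within the scatter). Among the measured compounds shown here, that step lies within the scatter, and it concerns a different place in the molecule, so it shows only that one change elsewhere left the number in place. For the measured compounds named here, no measured pair moves the chlorine, so the data give no direct guide to the size of this step. Going by the values given here, no step clearly beyond the scatter is therefore expected, with a slight lean to a higher number, as compound 1 at 90 nM is the lowest so far. The expected change is a 1.3-fold higher number from compound 1 to compound 4 (0.12 log units; within the scatter). For compound 4 the estimated value is 120 nM, with an expected range from 45 nM to 320 nM.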

Compound 4, concentration for 50% growth inhibition: 60 nM
The estimate for compound 4 lay 2.0-fold (0.30 log units) above the measured number; measured number inside the range.
By their numbers in this assay, from the lowest: compounds 4 and 1 (each within the scatter of the next); then compounds 2 and 3 (each within the scatter of the next).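

In this assay, putting 3-chlorophenyl in place of 4-chlorophenyl on a nitrogen on an aromatic ring gives a 1.5-fold lower number from compound 1 to compound 4 (0.18 log units; within the scatter). This is the only step shown at this position, and it adds what the earlier compounds could not: the number stays in place when the chlorine moves around the phenyl ring, so compounds 1 and 4 cannot be told apart in this growth read-out. Nothing available on these compounds bears on this result.

Whether the chlorine itself matters remains open, since no compound shown pairs either chlorophenyl with a plain phenyl under the same chain. From the compounds shown here alone, it is equally open how this position would respond to a larger change, such as a phenyl carrying a methoxy group, an amine or a carboxylic acid.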